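The source may hold more compounds than are shown below. What is called first, only, known or untested is meant among the compounds shown, and "the series" means these compounds.

Going by the values given here, compound 2 `O=C(C[C@@H](CCCC1CCCCC1)c1nc(C(=O)N2CCCC2)no1)NO` gives 43 nM in an assay on CHO cells for inhibition of bone morphogenetic protein 1 (Homo sapiens), read by fluorescence (on this read-out higher numbers stand for weaker inhibition and lower numbers for stronger inhibition), the higher of the two numbers so far; compound 1 `O=C(O)CNC(=O)c1noc([C@H](CCCC2CCCCC2)CC(=O)NO)n1` gives 21 nM, and the step of a 2.0-fold higher number from compound 1 to compound 2 (0.31 log units; beyond the scatter) is the only measured change at this carbonyl carbon. Compound 3 `CN1CCN(CN(C)C(=O)c2noc([C@H](CCCC3CCCCC3)CC(=O)NO)n2)CC1` differs from compound 2 by methyl((4-methylpiperazin-1-yl)methyl)amino in place of pyrrolidin-1-yl on a carbonyl carbon. Because the step of a 2.0-fold higher number from compound 1 to compound 2 (0.31 log units; beyond the scatter) at the same position was modest, the change to compound 3 is expected to stay within a similar span with no clear direction, the estimated step being a 1.2-fold higher number from compound 2 to compound 3 (0.07 log units; within the scatter). Compound 3 is accordingly estimated at 50 nM in this assay, in the range 15 nM to 160 nM.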

Compound 3, half-maximal inhibitory concentration: 54 nM
Compound 3: the middle estimate sits 1.1-fold (0.03 log units) below what was measured; the measured number falls inside the stated range.
By their numbers in this assay, from the lowest: compound 1; then compounds 2 and 3 (each within the scatter of the next).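

In this assay methyl((4-methylpiperazin-1-yl)methyl)amino, with 10 heavy atoms against 5 in pyrrolidin-1-yl, gives only a 1.3-fold higher number from compound 2 to compound 3 (0.10 log units; within the scatter) on this carbonyl carbon, so the larger group brings no readable change. Measured against (carboxymethyl)amino, the same group gives a 2.6-fold higher number from compound 1 to compound 3 (0.41 log units; beyond the scatter) and so compound 2 and compound 3 both stand apart from compound 1. No supporting data bear on the reason for these numbers.

Still open, going by these compounds, is whether a longer chain ending in a carboxylic acid, such as (2-carboxyethyl)amino, would match compound 1. On these data alone, the outcome with a simple amino group on this carbonyl carbon is also open.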